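Aryl variation on the shared core

This account rests on a few compounds, and the source may have more. Where it says the series, first, only, none or still open, it means among the compounds named here.

Three compounds share one core and differ at a single point each. Compound 1 `COc1nc(-c2nc3ccccc3n2C)cc(-c2ccccc2)c1C#N` carries a phenyl group on an aromatic carbon of that core; in a functional assay on aorta (Rattus norvegicus, strain Wister) (a higher number here means a weaker inhibitor, a lower number a stronger inhibitor), compound 1 gives 300000 nM. Compound 2 `COc1nc(-c2nc3ccccc3n2C)cc(-c2ccc(Cl)cc2Cl)c1C#N` carries 2,4-dichlorophenyl at the same carbon, and in this assay compound 2 gives 214000 nM. Compound 3 `CCOc1nc(-c2nc3ccccc3n2C)cc(-c2ccc(Cl)cc2Cl)c1C#N` differs from compound 2 by a methyl in place of hydrogen on the saturated chain carbon bound to an oxygen on the aromatic ring, and in this assay compound 3 gives 305000 nM. Compound 2 has the lowest of the three numbers, but both gaps to it lie within the scatter: a 1.4-fold lower number from compound 1 to compound 2 (0.15 log units; within the scatter) and a 1.4-fold higher number from compound 2 to compound 3 (0.15 log units; within the scatter).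

Compound 4 `COc1nc(-c2nc3ccccc3n2C)cc(-c2ccc(C)cc2)c1C#N` is not yet measured. Its difference from compound 2: 4-methylphenyl in place of 2,4-dichlorophenyl on an aromatic carbon. Among the measured compounds shown here, the one measured step that bears on this exchange of aryl groups is a 1.4-fold lower number from compound 1 to compound 2 (0.15 log units; within the scatter), which stayed within the scatter, and the other step of a 1.4-fold higher number from compound 2 to compound 3 (0.15 log units; within the scatter) did likewise. Nothing among these three compounds points to a change beyond the scatter when the aryl group is altered again, so in this assay a step of about a 1.2-fold higher number from compound 2 to compound 4 (0.07 log units; within the scatter) is expected. Compound 4 is therefore estimated at 250000 nM in this assay, with an expected range from 120000 nM to 520000 nM. At numbers this large, a limit rather than a value is also possible.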

Compound 4, half-maximal inhibitory concentration: 295000 nM
For compound 4 the middle estimate is 1.2-fold (0.07 log units) below the measured one, within the range that was stated.
By their numbers in this assay, from the lowest: compounds 2, 4, 1 and 3 (each within the scatter of the next).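

At the aromatic carbon opposite the ring nitrogen, 4-methylphenyl in place of 2,4-dichlorophenyl gives, in this assay, a 1.4-fold higher number from compound 2 to compound 4 (0.14 log units; within the scatter) and so extends the aryl comparison from a chlorine-bearing group to one carrying only carbon. Methyl in place of hydrogen on the same aryl group gives a 1.0-fold lower number from compound 1 to compound 4 (0.01 log units; within the scatter), which isolates a single substituent on the plain phenyl and likewise stays within the scatter. Phenyl, 2,4-dichlorophenyl and 4-methylphenyl at this carbon therefore cannot be told apart in this assay, and no supporting data are available to account for this flat response.

Going by these compounds, every aryl group here is a six-membered ring of carbon only, so it remains open whether a pyridyl ring, or a phenyl ring bearing an amine or a carboxylic acid, would move the number beyond the scatter at this carbon. Also open, on these data alone, is whether a longer chain on the oxygen would do so, and whether changes at that oxygen and at the aryl group would act independently of one another.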